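Removing a Fluorine: A Small Step Tested

This account rests on a few compounds, and the source may have more. Where it says the series, first, only, none or still open, it means among the compounds named here.

Of the compounds shown here, three have been tested in a functional assay on MCF7 cells (Homo sapiens) for cytotoxicity, read by MTT assay, with a stated time of 72 h; a lower number here means that less compound is tolerated, a higher number that more compound is tolerated. Compound 1 `CC(C)COC(=O)Nc1ccc([Se][Se]c2ccc(NC(=O)OCC(C)C)cc2)cc1` gives 80500 nM, compound 3 `O=C(Nc1ccc([Se][Se]c2ccc(NC(=O)OCc3ccc([N+](=O)[O-])cc3)cc2)cc1)OCc1ccc([N+](=O)[O-])cc1` gives 85000 nM, and compound 2 `N#C[Se]c1ccc(NC(=O)Oc2ccc(F)cc2)cc1` gives 65700 nM. Compound 2 has the lowest number of the three, yet its gap to compound 1 and its gap to compound 3 both lie within the scatter of repeated measurements, so the three values cannot be separated with confidence.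

Compound 4 `N#C[Se]c1ccc(NC(=O)Oc2ccccc2)cc1` differs from compound 2 in one place: hydrogen in place of fluoro on an aromatic carbon. For the measured compounds named here, no pair of measured compounds shows this change, so nothing in the data sets its size directly. The measured values sit close together and the change itself is small, so the expected outcome is modest. In this assay the expected step is a 1.1-fold higher number from compound 2 to compound 4 (0.03 log units; within the scatter), which amounts to none beyond the scatter. Compound 4 is therefore estimated to give 70000 nM, with a likely range from 35000 nM to 140000 nM.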

Compound 4, concentration lethal to 50% of the cells in the MCF7 assay: 67800 nM
Compound 4: the middle estimate sits 1.0-fold (0.01 log units) above what was measured, within the range that was stated.
By their numbers in the MCF7 assay, from the lowest: compounds 2, 4, 1 and 3 (each within the scatter of the next).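

For the compounds shown here, in the MCF7 assay putting hydrogen in place of fluoro on this aromatic carbon gives the first direct reading of this change, a 1.0-fold higher number from compound 2 to compound 4 (0.01 log units; within the scatter) so at this place, para to a large group, the two atoms cannot be told apart in this assay. In a physicochemical assay, with a stated time of 6 min, tested at 0.1 mg/mL (on this read-out lower numbers stand for less inhibition and higher numbers for more inhibition at the one concentration tested (going by the name of the read-out)), compound 2 gives > 25% as a limit of the assay and not a number. In the physicochemical assay compound 4 gives > 25% as a limit too, so the step between the two compounds cannot be read: the limit of > 25% in the physicochemical assay, at which 2 of the 2 values shown sit.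

The compounds shown leave open whether a different group at this place, such as an amine or a carboxylic acid, would shift the cell result beyond the scatter. They also leave open where compound 2 and compound 4 truly stand in the physicochemical assay as exact numbers.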